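Swapping the Aryl Group on the Shared Core: Compound 4

The compounds below may be only part of what the source reports. "The series", "measured", "known", "first", "only" and "open" are said of these compounds alone.

Three compounds have been measured in an assay for binding affinity to dual specificity mitogen-activated protein kinase kinase 4 (Homo sapiens), read by KINOMEscan, tested at 100 nM; on this read-out higher numbers stand for a weaker effect at the one concentration tested and lower numbers for a stronger effect:

Compound 1, `CCCS(=O)(=O)Nc1ccc(F)c(C(=O)c2n[nH]c3ncc(-c4cccc(OC)c4)cc23)c1F`, gives 6.3%
Compound 2, `CCCS(=O)(=O)Nc1ccc(F)c(C(=O)c2n[nH]c3ncc(-c4ccc(N)cc4)cc23)c1F`, gives 0.1%
Compound 3, `CCCS(=O)(=O)Nc1ccc(F)c(C(=O)c2n[nH]c3ncc(-c4ccc(OC)cc4Cl)cc23)c1F`, gives 5.3%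

Compound 3 stands second highest of these three numbers; compound 1 is nearest and compound 2 furthest, and both gaps lie within the scatter, so the three read alike. Compound 4, `CCCS(=O)(=O)Nc1ccc(F)c(C(=O)c2n[nH]c3ncc(-c4cccc(C(F)(F)F)c4)cc23)c1F`, comes from compound 3 by 3-(trifluoromethyl)phenyl in place of 2-chloro-4-methoxyphenyl on an aromatic carbon. The measured steps that bear on this change all swap the group on the same aromatic carbon: a number 1 percentage points lower from compound 1 to compound 3 (within the scatter), a number 5.2 percentage points higher from compound 2 to compound 3 (within the scatter) and a number 6.2 percentage points lower from compound 1 to compound 2 (within the scatter). None of them moved beyond the scatter. Among the compounds with values here, no measured step brings in a trifluoromethyl group, so that part of the change has no direct precedent. Compound 4 is therefore expected to give a step of a number 0.3 percentage points lower from compound 3 to compound 4 (within the scatter), not beyond the scatter in either direction. In this assay compound 4 is estimated at 5%, expected to fall between 0.5% and 20%.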

Compound 4, a percentage reported as activity, at one concentration (the size of the read-out at that concentration, not a potency): 57%
Estimate against measurement, compound 4: 52 percentage points below; the whole stated range lies below it.
By their numbers in this assay, from the lowest: compounds 2, 3 and 1 (each within the scatter of the next); then compound 4.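

In this assay this aromatic carbon of the shared core does not accept every aryl group alike: the three earlier groups read alike, yet 3-(trifluoromethyl)phenyl gives a number 51.7 percentage points higher from compound 3 to compound 4 (beyond the scatter) and a number 56.9 percentage points higher from compound 2 to compound 4 (beyond the scatter). The clearest comparison is trifluoromethyl in place of methoxy, with a number 50.7 percentage points higher from compound 1 to compound 4 (beyond the scatter), so changing one substituent on the phenyl ring can be enough to weaken the effect at the one concentration tested. Nothing at hand gives a reason for this large step.

Going by these compounds, it remains open whether the loss is specific to trifluoromethyl or would also appear with a nitrile, a methyl group or a carboxylic acid in its place. On these data alone, the read-out is also not a potency, so how far binding strength changes remains unknown.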